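Trifluoromethyl to fluoro: what should compound 4 do?

A few compounds are considered here, and "the series" means these few. Any claim that something is new, unique, unknown or untested is made for them only; others in the source may bear on it.

Results in a functional assay on HeLa cells (Homo sapiens) for inhibition, with a stated time of 72 h; on this read-out lower numbers stand for an effect already at smaller amounts and higher numbers for an effect only at larger amounts of compound
- compound 1 `COc1cc(CNC2CCCCC2)ccc1OCc1ccc(Cl)nc1` gives "nd(insoluble)" (no result reported)
- compound 2 `Clc1ccc(COc2ccc(CNCc3ccncc3)cc2)cc1` gives 4000 nM
- compound 3 `COc1cc(CNCc2ccncc2)ccc1OCc1ccc(C(F)(F)F)cc1` gives 2400 nM

Only two of these compounds have a number, and compound 3 lies within the usual scatter of compound 2. Compound 1 offers no number to compare with. The next compound, compound 4 (`COc1cc(CNCc2ccncc2)ccc1OCc1ccc(F)cc1`), keeps the frame of compound 3 but carries fluoro in place of trifluoromethyl on an aromatic carbon, para to a large group (fluoro in place of trifluoromethyl on an aromatic carbon). Among the compounds with values here, no measured pair shows this change alone, so the expectation has little to rest on. Within the data shown here, the only guide is that compound 2 at (4000 nM) and compound 3 at (2400 nM) sit close together despite their differing structures. In this assay, no shift beyond the scatter is expected, and the expected step (a 1.5-fold higher number from compound 3 to compound 4 (0.16 log units; within the scatter)) leans only slightly towards a higher number. The estimated value for compound 4 is 3500 nM (expected range 1500 nM to 8000 nM).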

Compound 4, half-maximal effective concentration: 6400 nM
Beside the measured number, compound 4's estimate is 1.8-fold (0.26 log units) below it; measured number inside the range.
By their numbers in this assay, from the lowest: compounds 3, 2 and 4 (each within the scatter of the next, the first and the last beyond it).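

In this assay, within the data shown here, putting fluoro in place of trifluoromethyl on an aromatic carbon, para to a large group, gives a 2.7-fold higher number from compound 3 to compound 4 (0.43 log units; beyond the scatter) and is the only step here between compounds that differ in one place. It shows that this position is not indifferent to its group: with the rest of the molecule unchanged, the swap from four heavy atoms to one goes with a higher number, so more compound is needed for the same effect. Nothing measured here explains this shift.

A single step cannot separate the number of atoms in the group from any other difference between these two groups. On these data alone, it also remains open whether a nitrile or a carboxylic acid at this same place would fall nearer compound 3 or compound 4, or outside both.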